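This account rests on a few compounds, and the source may have more. Where it says the series, first, only, none or still open, it means among the compounds named here.

Compound 1 `CN(C)CCN(C)c1ccc(C#N)c(CN2CCN(C(c3ccccc3)c3ccccc3)CC2)c1` gives > 20000 nM (a limit)
Compound 2 `CN(C)CCN(C)c1ccc(C#N)c(CN2CCN(C(c3ccc(Cl)cc3)c3ccc(Cl)cc3)CC2)c1` gives 3330 nM
Compound 3 `N#Cc1ccc(NCCCn2ccnc2)cc1CN1CCN(C(c2ccc(Cl)cc2)c2ccc(Cl)cc2)CC1` gives > 20000 nM (a limit)

Among the measured compounds shown here, in a toxicity assay on Huh-7.5 cells (Homo sapiens) for cytotoxicity, read by MTT assay, with a stated time of 96 h (on this read-out lower numbers stand for higher toxicity in this test and higher numbers for lower toxicity in this test), compound 2 gives 3330 nM as the only true number here. The values of the other two compounds are limits. Compound 4 `CN(C)CCN(C)c1ccc(C#N)c(CN2CCN(C(c3ccccc3)c3ccc(Cl)cc3)CC2)c1` differs from compound 2 by hydrogen in place of chloro on an aromatic carbon so that 4-chlorophenyl becomes phenyl. For the measured compounds named here, the one measured step of an at least 6.0-fold higher number from compound 2 to compound 3 (0.77 log units; beyond the scatter) changes another part of the molecule and offers only indirect guidance. Closer is compound 1, which has phenyl in both places and gives > 20000 nM as a limit, so removing one chloro from compound 2 should modestly raise the number. The expected result is a 2.4-fold higher number from compound 2 to compound 4 (0.38 log units; beyond the scatter) on this read-out. Compound 4 may instead reach the limit of > 20000 nM in this assay, at which 2 of the 3 values shown sit, and give no number. Compound 4 is estimated at 8000 nM with a range from 4000 nM to 20000 nM expected.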

Compound 4, half-maximal cytotoxic concentration: 5660 nM
The estimate for compound 4 lay 1.4-fold (0.15 log units) above the measured number; the range from low to high includes it.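

In this assay, hydrogen in place of chloro on one aromatic ring gives a 1.7-fold higher number from compound 2 to compound 4 (0.23 log units; within the scatter), so losing this one chloro makes no clear difference. The other step shows that a single chloro on a phenyl ring does register, with an at least 3.5-fold lower number from compound 1 to compound 4 (0.54 log units; beyond the scatter). The value of compound 1 is a limit and not a number, so the true size of that step stays unknown: the limit of > 20000 nM in this assay, at which 2 of the 4 values shown sit.

On these data alone, what a fluoro or a methoxy group would do on this aromatic carbon stays open. So does whether a single chloro would count the same with the (3-(1H-imidazol-1-yl)propyl)amino group of compound 3.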